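From 2,3-dihydroxypropoxy to 3-carboxypropoxy

This account rests on a few compounds, and the source may have more. Where it says the series, first, only, none or still open, it means among the compounds named here.

In an ADME assay on S9 fraction from liver (Rattus norvegicus, strain Sprague-Dawley) for metabolic stability, read by LC-MS, using NADPH, with stated times of 5 min and 60 min, tested at 5 uM (a higher number here means that more of the compound is left, a lower number that less of the compound is left), the measured compounds so far are these
Compound 1 `COc1cc(C2CN(C(=O)c3cc(OC[C@H](O)CO)ccn3)C2)ccc1OCc1ccc(C2CC2)cc1` (67%)
Compound 2 `COc1cc(C2CN(C(=O)c3cc(OC[C@@H](O)CO)ccn3)C2)ccc1OCc1ccc(C2CC2)cc1` (61%)

Compound 2 cannot be told apart from compound 1 on these numbers. Going by the values given here, the only measured step is a number 6 percentage points lower from compound 1 to compound 2 (within the scatter) and what separates the pair is the fact that compounds 1 and 2 differ only in the configuration as drawn alone. Compound 3 `COc1cc(C2CN(C(=O)c3cc(OCCCC(=O)O)ccn3)C2)ccc1OCc1ccc(C2CC2)cc1` alters the chain instead: 2-carboxyethyl in place of 1,2-dihydroxyethyl on a saturated chain carbon bound to an oxygen on an aromatic ring (2,3-dihydroxypropoxy to 3-carboxypropoxy, on the same shared core). Among the compounds with values here, no measured step tests a change of group, so no direction can be read from the data. A step of a number 1 percentage points higher from compound 2 to compound 3 (within the scatter) is expected, which is none beyond the scatter. Compound 3 is estimated at 62% (range 42% to 80%).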

Compound 3, percent of the compound remaining: 100%
Compound 3: the middle estimate sits 38 percentage points below what was measured, and the stated range ends below it.
By their numbers in this assay, from the lowest: compounds 2 and 1 (each within the scatter of the next); then compound 3.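

Swapping 1,2-dihydroxyethyl for 2-carboxyethyl on a saturated chain carbon bound to an oxygen on an aromatic ring moves the number in this assay far more than the drawn configuration did. The step is a number 39 percentage points higher from compound 2 to compound 3 (beyond the scatter), and it is a number 33 percentage points higher from compound 1 to compound 3 (beyond the scatter). Either starting compound therefore gives a large step, and the comparison of the two starts rests on one fact: the fact that compounds 1 and 2 differ only in the configuration as drawn

From the compounds shown here alone, whether the carboxylic acid or the longer chain matters remains open. An amine or a primary amide at the chain end could help separate the two.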